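Hydroxy in place of iodo on the benzyl ring

This account rests on a few compounds, and the source may have more. Where it says the series, first, only, none or still open, it means among the compounds named here.

Compound 1 `O=c1cc(CNCc2ccccc2)oc2ccc(O)c(O)c12` gives > 100000 nM in an ADME assay on Huh-7 cells (Homo sapiens) for cytotoxicity (on this read-out lower numbers stand for higher toxicity in this test and higher numbers for lower toxicity in this test), a limit of the assay.
Compound 2 `O=c1cc(CNCc2ccccc2Br)oc2ccc(O)c(O)c12` gives > 100000 nM in this assay, again a limit.
Compound 3 `O=c1cc(CNCc2ccccc2I)oc2ccc(O)c(O)c12` gives 87300 nM in this assay.

For the measured compounds named here, compound 3 therefore holds the only number among the three; the two others stand at the limit of > 100000 nM in this assay, at which 2 of the 3 values shown sit. The step from compound 1 to compound 3 reads an at least 1.1-fold lower number from compound 1 to compound 3 (0.05 log units; that floor lies within the scatter), and the step from compound 2 to compound 3 reads an at least 1.1-fold lower number from compound 2 to compound 3 (0.05 log units; that floor lies within the scatter). Both are floors that lie within the scatter, and the step that the two limits leave unreadable from compound 1 to compound 2 cannot be read at all.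

Compound 4 `O=c1cc(CNCc2ccccc2O)oc2ccc(O)c(O)c12` differs from compound 3 by hydroxy in place of iodo on an aromatic carbon. The measured steps give no sign that any change at this place moves the read-out beyond the scatter. Compound 4 is thus expected to sit close to compound 3, with an estimated step of a 1.1-fold higher number from compound 3 to compound 4 (0.06 log units; within the scatter), and the value is expected to return to the region of the limit. The estimate for compound 4 in this assay is 100000 nM, within 50000 nM to 200000 nM.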

Compound 4, half-maximal cytotoxic concentration: > 100000 nM
Compound 4 gave a limit, no number; the forecaster's own chance of this, stated with the estimate: 60%; the middle value lies on the limit itself.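

For the compounds shown here, compound 4 brings a hydroxy group, with a hydrogen-bond donor and acceptor, to a place that had so far held only hydrogen, bromo and iodo, and in this assay the only readable step is still a floor: an at least 1.1-fold higher number from compound 3 to compound 4 (0.05 log units; that floor lies within the scatter). The steps to compound 4 from compound 1 and from compound 2 cannot be read, as both ends of each are limits. This place has now taken four different substituents without any step that reads beyond the scatter, and compound 3 remains the only one with a number, while the rest share one limit: the limit of > 100000 nM in this assay, at which 3 of the 4 values shown sit.

The values of compound 1, compound 2 and compound 4 remain unresolved. Going by these compounds, whether an amine or a carboxylic acid at this place would give a step beyond the scatter also stays open.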